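This account rests on a few compounds, and the source may have more. Where it says the series, first, only, none or still open, it means among the compounds named here.

Measured in a physicochemical assay for solubility, with a stated time of 24 h, tested at 30 mg/mL; on this read-out higher numbers stand for higher solubility and lower numbers for lower solubility:
compound 1 `O=C(CCCCCNc1c(Nc2ccc(C(F)(F)F)cc2)c(=O)c1=O)NO` gives 4700000 nM
compound 2 `CC(CCCCC(=O)NO)Nc1c(Nc2ccc(C(F)(F)F)cc2)c(=O)c1=O` gives 20000000 nM
compound 3 `CCC(CCCCC(=O)NO)Nc1c(Nc2ccc(C(F)(F)F)cc2)c(=O)c1=O` gives 25000000 nM

Compound 3 carries the top number of the three in this assay. Its gap from compound 1 is clear (a 5.3-fold higher number from compound 1 to compound 3 (0.73 log units; beyond the scatter)), whereas the gap from compound 2 is not (a 1.3-fold higher number from compound 2 to compound 3 (0.10 log units; within the scatter)), so compound 2 and compound 3 are read as a pair at the same level.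

The next compound is compound 4 `CC(C)C(CCCCC(=O)NO)Nc1c(Nc2ccc(C(F)(F)F)cc2)c(=O)c1=O`. It differs from compound 3 by methyl in place of hydrogen on a saturated chain carbon bound to two saturated chain carbons.

Two measured steps put a group on the saturated chain carbon bound to the nitrogen and lift the number by a modest amount: a 4.3-fold higher number from compound 1 to compound 2 (0.63 log units; beyond the scatter) and a 5.3-fold higher number from compound 1 to compound 3 (0.73 log units; beyond the scatter). The step that most resembles the present one adds a methyl further along the chain and stays within the scatter: a 1.3-fold higher number from compound 2 to compound 3 (0.10 log units; within the scatter). On that basis the step to compound 4 is expected to be small, possibly none beyond the scatter, with a slight lean upward: a 1.1-fold higher number from compound 3 to compound 4 (0.05 log units; within the scatter).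

For compound 4 the estimated value in this assay is 28000000 nM, with a range from 12000000 nM to 50000000 nM.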

Compound 4, solubility: 6300000 nM
Compound 4: middle estimate off by 4.4-fold (0.65 log units), on the high side; measured number outside the range, below it.
By their numbers in this assay, from the lowest: compounds 1 and 4 (each within the scatter of the next); then compounds 2 and 3 (each within the scatter of the next).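

In this assay, the lift seen on the saturated chain carbon bound to the nitrogen does not carry through to isopropyl: ethyl to isopropyl brings the number down (a 4.0-fold lower number from compound 3 to compound 4 (0.60 log units; beyond the scatter)), and the change from methyl to isopropyl does the same (a 3.2-fold lower number from compound 2 to compound 4 (0.50 log units; beyond the scatter)). Compared with the unbranched chain of compound 1, the gain is gone (a 1.3-fold higher number from compound 1 to compound 4 (0.13 log units; within the scatter)), so across compounds 1, 2, 3 and 4 the number does not follow the size of the group in one direction. No measurement at hand accounts for this turn.

Going by these compounds, whether the fall goes with branching at this carbon or with the carbon count of the group stays open. A straight propyl or a cyclopropyl group on the same carbon would separate the two readings.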